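From methoxy to hydroxy on a nitrooxy ester

A few compounds are considered here, and "the series" means these few. Any claim that something is new, unique, unknown or untested is made for them only; others in the source may bear on it.

In a functional assay on HOP-62 cells (Homo sapiens) for cytotoxicity, read by resazurin assay, with a stated time of 72 h (on this read-out higher numbers stand for weaker inhibition and lower numbers for stronger inhibition), the measured compounds read as follows
Compound 1 `COc1cc(/C=C/C(=O)OCCCCCCO[N+](=O)[O-])ccc1O` gives > 50000 nM (a limit)
Compound 2 `COc1cc(/C=C/C(=O)OCCCO[N+](=O)[O-])ccc1OCCCO[N+](=O)[O-]` gives > 50000 nM (a limit)
Compound 3 `COc1cc(/C=C/C(=O)OCCCO[N+](=O)[O-])ccc1O` gives 19400 nM (a true number)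

Compound 2 has no exact number, only the limit of > 50000 nM in this assay, at which 2 of the 3 values shown sit (a limit). Compound 4 `O=C(/C=C/c1ccc(OCCCO[N+](=O)[O-])c(O)c1)OCCCO[N+](=O)[O-]` differs from it thus: hydrogen in place of methyl on an oxygen on an aromatic ring (methoxy to hydroxy). The closest measured change is an at least 2.5-fold lower number from compound 2 to compound 3 (0.41 log units; beyond the scatter) (it also puts hydrogen on an oxygen on an aromatic ring, though in place of 3-(nitrooxy)propyl). The other change, an at least 2.5-fold lower number from compound 1 to compound 3 (0.41 log units; beyond the scatter) (on a saturated chain carbon), bears on this less. Going by these compounds, both steps start from a limit, so their full size is unknown. A modest move toward a lower number is therefore expected, and an at least 1.6-fold lower number from compound 2 to compound 4 (0.22 log units; that floor lies within the scatter) in this assay is the estimated step. For compound 4 the estimated value is 30000 nM, with an expected range of 12000 nM to 70000 nM (an estimate).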

Compound 4, half-maximal inhibitory concentration: 10000 nM
The estimate for compound 4 lay 3.0-fold (0.48 log units) above the measured number; measured number outside the range, below it.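

Methoxy to hydroxy gives an at least 5.0-fold lower number from compound 2 to compound 4 (0.69 log units; beyond the scatter) in this assay. So the methyl on this oxygen on an aromatic ring counts, even with the 3-(nitrooxy)propyl group kept on the other oxygen, whereas the earlier steps changed only that group or the saturated chain. Compound 2 carries a limit, so the full size of this step stays unknown: the limit of > 50000 nM in this assay, at which 2 of the 4 values shown sit.

Going by these compounds, whether an ethyl group on this oxygen would give a number nearer to that of compound 2 or of compound 4 stays open. So does the effect of an amine in place of the hydroxy.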